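The source may report more compounds than this note shows. Statements on the series, on what has been measured and on what is new or still open speak of the compounds shown alone.

Of the compounds shown here, two have been measured so far. In an assay on HEK293 cells for inhibition of transient receptor potential cation channel subfamily M member 8 (Homo sapiens), read by FLIPR, with stated times of 5 min and 3 min (on this read-out lower numbers stand for stronger inhibition and higher numbers for weaker inhibition), compound 1 `Cc1nnc(-c2sc(-c3cccc(F)c3)nc2O)o1` gives 9100 nM. Compound 2 `CCOC(=O)c1sc(-c2ccc(F)cc2)nc1O` gives 80 nM in this assay, the lower of the two numbers, with compound 1 sitting beyond the scatter above it. Compound 3 `CCOC(=O)c1sc(-c2ccc(Cl)cc2)nc1O` is not yet measured; it differs from compound 2 by chloro in place of fluoro on an aromatic carbon. Among the compounds with values here, no measured pair shows this same change, so there is no step to lean on. The step is expected to be small, a 1.3-fold lower number from compound 2 to compound 3 (0.12 log units; within the scatter), staying within the scatter. Compound 3 is therefore estimated at 60 nM, between 25 nM and 200 nM.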

Compound 3, half-maximal inhibitory concentration: 550 nM
Compound 3: the middle estimate sits 9.2-fold (0.96 log units) below what was measured; measured number above the stated range.
By their numbers in this assay, from the lowest: compound 2; then compound 3; then compound 1.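

Changing fluoro to chloro on this aromatic carbon, para to a large group, gives a 6.9-fold higher number from compound 2 to compound 3 (0.84 log units; beyond the scatter) in this assay, so the exchange of one halogen for another is not neutral here. Among these two compounds, fluoro gives the stronger inhibition, and the position responds to a change of only one heavy atom. Nothing shown accounts for this difference.

The compounds shown leave open how a methyl, methoxy or bromo group at this position would compare with fluoro and chloro. They also leave open whether an unsubstituted carbon here would read closer to compound 2 or to compound 3.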